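This account rests on a few compounds, and the source may have more. Where it says the series, first, only, none or still open, it means among the compounds named here.

Measured compounds:
compound 1, `CC(C)[C@H](C(=O)Nc1ccc(F)cn1)c1ccc(Cl)cc1`, 93% in a functional assay on CHO cells for agonist activity at Free fatty acid receptor 2 (Homo sapiens), read by cAMP accumulation; on this read-out lower numbers stand for smaller maximal responses and higher numbers for larger maximal responses
compound 2, `CC(C)[C@H](C(=O)Nc1nncs1)c1ccc(Cl)cc1`, 115%
compound 3, `CC(C)[C@H](C(=O)Nc1ncns1)c1ccc(Cl)cc1`, 99%

All three share one core and differ only in the aromatic ring carried on the amide-type nitrogen. Compound 3 stands second highest of the three numbers: its nearest neighbour is compound 1, which lies a little lower, within the scatter, while compound 2 lies further off, a number 16 percentage points lower from compound 2 to compound 3 (beyond the scatter). The other two steps are a number 22 percentage points higher from compound 1 to compound 2 (beyond the scatter) and a number 6 percentage points higher from compound 1 to compound 3 (within the scatter).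

Compound 4, `CC(C)[C@H](C(=O)Nc1ccon1)c1ccc(Cl)cc1`, has not yet been measured in this assay. It differs from compound 3 in one place: 1,2-oxazol-3-yl in place of 1,2,4-thiadiazol-5-yl on an amide-type nitrogen.

Within the data shown here, the steps that bear on this change are those that swap one small aromatic ring for another on the same amide-type nitrogen. Each of them was modest or within the scatter, so a ring swap at this place has so far shifted the maximal response only slightly. On that basis the step to compound 4 is expected to be small, a number 2 percentage points lower from compound 3 to compound 4 (within the scatter), with no clear direction. The estimate for compound 4 is therefore 97%, expected to fall between 78% and 116%.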

Compound 4, largest response reached (reported as efficacy), in percent of the reference or control that the assay uses: 90%
Beside the measured number, compound 4's estimate is 7 percentage points above it; measured number inside the range.
By their numbers in this assay, from the lowest: compounds 4, 1 and 3 (each within the scatter of the next); then compound 2.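

In this assay, 1,2-oxazol-3-yl on the amide-type nitrogen cannot be told apart from two of the earlier rings: the change from 1,2,4-thiadiazol-5-yl gives a number 9 percentage points lower from compound 3 to compound 4 (within the scatter), and the change from 5-fluoropyridin-2-yl gives a number 3 percentage points lower from compound 1 to compound 4 (within the scatter). The widest ring swap so far at this position is a number 25 percentage points lower from compound 2 to compound 4 (beyond the scatter), which leaves compound 2 alone, beyond the scatter of compounds 1, 3 and 4, while the other three form one group. A thiadiazole ring as such therefore does not set a compound apart, since compound 3 carries one and stays with compounds 1 and 4, and nothing at hand explains what distinguishes the 1,3,4-thiadiazol-2-yl ring of compound 2.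

The compounds shown leave open whether a plain phenyl or a saturated cyclohexyl on the same amide-type nitrogen would fall within this group of three or reach the level of compound 2. They also leave open whether compound 2 would keep its separation with a methoxy group in place of the chlorine on the shared core.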